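Thiazole for Chloropyrazine on the Amide Carbonyl

The source may report more compounds than this note shows. Statements on the series, on what has been measured and on what is new or still open speak of the compounds shown alone.

Of the compounds shown here, two of a shared core have been measured in an in vivo ADME assay on the whole organism (strain Mongrel) for pharmacokinetics, with Canis familiaris (Canis lupus familiaris) as the target; on this read-out lower numbers stand for slow clearance and higher numbers for fast clearance. Compound 1 `COc1ncc(C(=O)NC2(C(=O)N[C@H](C)c3ccc(-n4nc(Cl)c5ccccc54)cc3F)CC2)s1` gives 1.7 mL/min/kg. For the measured compounds named here, compound 2 `C[C@@H](NC(=O)C1(NC(=O)c2cncc(Cl)n2)CC1)c1ccc(-n2nc(Cl)c3ccccc32)cc1F` gives 10.5 mL/min/kg, the higher of the two numbers, the only neighbour being compound 1 with a 6.2-fold higher number from compound 1 to compound 2 (0.79 log units; beyond the scatter). Compound 3 `C[C@@H](NC(=O)C1(NC(=O)c2cncs2)CC1)c1ccc(-n2nc(Cl)c3ccccc32)cc1F` is not yet measured; it differs from compound 2 in one place: 1,3-thiazol-5-yl in place of 6-chloropyrazin-2-yl on a carbonyl carbon. Going by the values given here, the only step that bears on this change is the one in this assay from compound 1 to compound 2, where the exchange of the group on the carbonyl carbon moved the number well beyond the scatter. Since the entering 1,3-thiazol-5-yl lacks the substituent seen in compound 1, a smaller shift in that direction is expected, a 2.1-fold lower number from compound 2 to compound 3 (0.32 log units; beyond the scatter). Compound 3 is therefore estimated at 5 mL/min/kg, with a range from 2 mL/min/kg to 12 mL/min/kg.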

Compound 3, clearance: 1.1 mL/min/kg
For compound 3 the middle estimate is 4.5-fold (0.66 log units) above the measured one, outside the stated range (below it).
By their numbers in this assay, from the lowest: compounds 3 and 1 (each within the scatter of the next); then compound 2.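

In this assay, the exchange of 6-chloropyrazin-2-yl for the smaller 1,3-thiazol-5-yl on the carbonyl carbon gives a 9.5-fold lower number from compound 2 to compound 3 (0.98 log units; beyond the scatter), so the bare thiazole does not need a substituent to reach the low range of this series. The methoxy group adds nothing that can be told apart here, with a 1.5-fold lower number from compound 1 to compound 3 (0.19 log units; within the scatter), and the two thiazoles stand together, apart from the chloropyrazine of compound 2. Nothing shown explains why clearance follows the ring in this way.

The compounds shown leave open whether the chlorine or the pyrazine ring goes with the higher number of compound 2, a question that a plain pyrazin-2-yl on the same carbonyl carbon would separate. They also leave open whether an amine in place of the methoxy on the thiazole would stay with compounds 1 and 3.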